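Cyclopentyl in Place of Vinyl: Expected Cytotoxicity of Compound 3

A few compounds are considered here, and "the series" means these few. Any claim that something is new, unique, unknown or untested is made for them only; others in the source may bear on it.

Compound 1 `C[C@H]1[C@H](NCc2cc(Br)cs2)C[C@H]2C[C@@H]1C2(C)C` and compound 2 `C=Cc1csc(CN[C@@H]2C[C@H]3C[C@@H]([C@H]2C)C3(C)C)c1` share one core. In an ADME assay on MDCK cells (Canis lupus familiaris) for cytotoxicity, read by microscopy, with a stated time of 48 h (on this read-out higher numbers stand for lower toxicity in this test and lower numbers for higher toxicity in this test), compound 1 gives 6250 nM, and compound 2 gives 6250 nM. The measured step reads no change at the digits printed from compound 1 to compound 2 (within the scatter). Compound 2 thus stands level with compound 1, with no difference beyond the scatter. Compound 3 `C[C@H]1[C@H](NCc2cc(C3CCCC3)cs2)C[C@H]2C[C@@H]1C2(C)C` differs from compound 2 in one place: cyclopentyl in place of vinyl on an aromatic carbon. Among the measured compounds shown here, the only step measured, which exchanged a bromo for a vinyl group on an aromatic carbon, left this assay unchanged, and no measured compound carries a cyclopentyl group. Compound 3 is therefore expected to show no step beyond the scatter, no change at the digits printed from compound 2 to compound 3 (within the scatter). Compound 3 is estimated at 6250 nM, within a range from 2500 nM to 15000 nM.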

Compound 3, minimum cytotoxic concentration: 1560 nM
Compound 3: middle estimate off by 4.0-fold (0.60 log units), on the high side; measured number outside the range, below it.
By their numbers in this assay, from the lowest: compound 3; then compounds 1 and 2 (each within the scatter of the next).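

In this assay cyclopentyl in place of vinyl gives a 4.0-fold lower number from compound 2 to compound 3 (0.60 log units; beyond the scatter) and cyclopentyl in place of bromo gives a 4.0-fold lower number from compound 1 to compound 3 (0.60 log units; beyond the scatter) on the same aromatic carbon. This position therefore does respond to its substituent, which the matching readings of bromo and vinyl had not shown. The shift runs toward higher toxicity in this test. On these data alone, whether a smaller ring such as cyclopropyl, an open chain such as n-pentyl, or an amine at this carbon would give the same reading stays open. Nothing available explains the step.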